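This account rests on a few compounds, and the source may have more. Where it says the series, first, only, none or still open, it means among the compounds named here.

In a functional assay on A549 cells (Homo sapiens) for antiproliferative activity, read by MTT assay, with a stated time of 48 h (on this read-out lower numbers stand for stronger inhibition and higher numbers for weaker inhibition), compound 1 `COc1ccc(-c2nc3cccc(-c4cc(OC)c(OC)c(OC)c4)c3o2)cc1` gives 2200 nM, compound 2 `COc1ccc(-c2nc3cccc(-c4cc(OC)c(OC)c(OC)c4)c3o2)cc1F` gives 1800 nM and compound 3 `COc1cc(-c2cccc3nc(-c4ccc(F)cc4)oc23)cc(OC)c1OC` gives 8700 nM, the highest number of the three. Compound 4 `COc1cc(-c2cccc3nc(-c4cccc(Br)c4)oc23)cc(OC)c1OC` carries 3-bromophenyl in place of 4-fluorophenyl on an aromatic carbon. Three measured steps alter this same aryl group: a 4.0-fold higher number from compound 1 to compound 3 (0.60 log units; beyond the scatter) and a 4.8-fold higher number from compound 2 to compound 3 (0.68 log units; beyond the scatter) are modest and beyond the scatter, while a 1.2-fold lower number from compound 1 to compound 2 (0.09 log units; within the scatter) stays within it. Within the data shown here, no bromo compound has been measured, so the basis is thin. Among the measured compounds shown here, both other aryl groups tested give lower numbers than compound 3, so a modest fall is expected in this assay, no larger than those steps. The expected change is a 1.9-fold lower number from compound 3 to compound 4 (0.29 log units; within the scatter). For compound 4 the estimate is 4500 nM, with an expected range of 1500 nM to 13000 nM.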

Compound 4, half-maximal inhibitory concentration: 2100 nM
Compound 4: middle estimate off by 2.1-fold (0.33 log units), on the high side; the measured number falls inside the stated range.
By their numbers in this assay, from the lowest: compounds 2, 4 and 1 (each within the scatter of the next); then compound 3.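

In this assay this position accepts 3-bromophenyl on a par with the methoxy-bearing aryl groups: a 1.2-fold higher number from compound 2 to compound 4 (0.07 log units; within the scatter) and a 1.0-fold lower number from compound 1 to compound 4 (0.02 log units; within the scatter) both lie within the scatter. A methoxy group on this aryl ring is therefore not required for this level among the listed compounds, and compound 3 stands apart, with a 4.1-fold lower number from compound 3 to compound 4 (0.62 log units; beyond the scatter) beyond the scatter. No measurement at hand explains this step.

The step changes both the halogen and its place on the ring, and 3-fluorophenyl and 4-bromophenyl would separate the two. Also open, from the compounds shown here alone, is how an aminophenyl or carboxyphenyl group would behave here.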